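Opening the pyrrolidine: a threonine replaces proline

The source may hold more compounds than are shown below. What is called first, only, known or untested is meant among the compounds shown, and "the series" means these compounds.

Among the measured compounds shown here, the two compounds measured so far share a core and differ only at one oxygen. Compound 1 `O=C(O)[C@@H]1CCCN1C(=O)CN(c1nc(Cl)nc2[nH]cnc12)C1CC1` carries a free acid; in a functional assay on the whole organism (Tail, strain ICR) with Mus musculus as the target, in the tail flick test, with a stated time of 60 min, at a dose of 25 umol/kg by the oral route (a higher number here means a stronger effect of the compound at the dose given, a lower number a weaker effect), compound 1 gives 34.9%. Compound 2 `O=C(OCc1ccccc1)[C@@H]1CCCN1C(=O)CN(c1nc(Cl)nc2[nH]cnc12)C1CC1` carries a benzyl ester there, and compound 2 gives 34.4%. For the measured compounds named here, the one step recorded, a number 0.5 percentage points lower from compound 1 to compound 2 (within the scatter), is within the scatter, so the two read-outs cannot be ordered. Compound 1 stands as the higher of the two numbers, but only by a margin the method does not resolve.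

Compound 3 `C[C@@H](O)[C@H](NC(=O)CN(c1nc(Cl)nc2[nH]cnc12)C1CC1)C(=O)O` is now to be measured. (1-carboxy-2-hydroxypropyl)amino in place of 2-carboxypyrrolidin-1-yl on a carbonyl carbon The change thus removes the ring while keeping an acid and adding a hydroxyl and an amide hydrogen. Going by the values given here, no recorded step touches this part of the molecule, since the single step known concerns only the ester oxygen. Among the compounds with values here, there is therefore nothing to say whether the step to compound 3 should be upward or downward; the only guidance is that one change nearby left the read-out untouched. The expectation for compound 3 is consequently a read-out near that of compound 1, with a number 4.9 percentage points lower from compound 1 to compound 3 (within the scatter) expected to lie within the scatter, and the estimate for compound 3 is 30%, ranging from 10% to 50%.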

Compound 3, a percentage reported as activity, at one dose (the size of the read-out at that dose, not a potency): 30.1%
Compound 3: middle estimate off by 0.1 percentage points, on the low side, within the range that was stated.
By their numbers in this assay, from the lowest: compounds 3, 2 and 1 (each within the scatter of the next).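

In this assay, the exchange of 2-carboxypyrrolidin-1-yl for (1-carboxy-2-hydroxypropyl)amino on a carbonyl carbon gives a number 4.8 percentage points lower from compound 1 to compound 3 (within the scatter), so these two read-outs cannot be ordered. The earlier step touched only the ester oxygen, whereas this one removes the five-membered ring altogether: the entering group has no ring, 3 hydrogen-bond donors instead of 1, and 2 defined stereocentres instead of 1, yet at this single dose the read-out shows no change beyond the scatter, so the ring is not required for an effect of this size. Nothing available explains why the read-out tolerates this exchange.

Going by these compounds, neither step has yet moved the read-out beyond the scatter, so it remains unknown what at this position, if anything, matters for the effect at this dose. On these data alone, it also remains open whether a simple amine or a longer alkyl chain on that carbonyl carbon, with no carboxyl group at all, would change the read-out, and whether a methoxy group in place of the hydroxyl would do so.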